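Fluoroethoxy in place of methoxy on a benzyl acetamide

This account rests on a few compounds, and the source may have more. Where it says the series, first, only, none or still open, it means among the compounds named here.

In an assay on HEK293 cells for displacement of a labelled ligand from Translocator protein (Homo sapiens), read by scintillation counting, with a stated time of 90 min (on this read-out lower numbers stand for stronger inhibition and higher numbers for weaker inhibition), three compounds have been measured. Compound 1 `CCN(CC)C(=O)Cn1c(-c2ccc(OC)cc2)cc2c(C)cc(C)cc21` gives 652 nM, compound 2 `CCN(CC)C(=O)c1nc2ccccc2n1Cc1ccc(Cl)cc1` gives 2570 nM, and compound 3 `COc1ccc(CN(C(C)=O)c2cc(C)cc(C)c2)cc1` gives 2790 nM. Compound 3 sits at the high end of the three numbers, alongside compound 2, whose value lies within the usual scatter of it, while compound 1 stands clearly lower, beyond the scatter.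

Compound 4 `CC(=O)N(Cc1ccc(OCCF)cc1)c1cc(C)cc(C)c1` has not yet been measured. It differs from compound 3 by fluoromethyl in place of hydrogen on a saturated chain carbon bound to an oxygen on an aromatic ring. Going by the values given here, no measured pair shows this change, so nothing here tells its direction. The step from compound 3 to compound 4 is expected to stay within the scatter, giving an estimated 1.1-fold lower number from compound 3 to compound 4 (0.05 log units; within the scatter). Compound 4 is therefore expected at about 2500 nM, between 1000 nM and 6000 nM.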

Compound 4, inhibition constant: 3930 nM
Compound 4: the middle estimate sits 1.6-fold (0.20 log units) below what was measured; the range from low to high includes it.
By their numbers in this assay, from the lowest: compound 1; then compounds 2, 3 and 4 (each within the scatter of the next).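

In this assay, going by these compounds alone, this is the first pair that differs in one place, and it reads a 1.4-fold higher number from compound 3 to compound 4 (0.15 log units; within the scatter). Going from methoxy to 2-fluoroethoxy therefore gives no step clear of the scatter, so fluoromethyl is tolerated in place of hydrogen on a saturated chain carbon bound to an oxygen on an aromatic ring. No supporting data bear on this result. Going by these compounds, whether an amine, a carboxylic acid or a longer chain would be tolerated there stays open. So does whether this change would read the same on the core of compound 1.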